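Fluoro for Methyl on the Indazole Arm

The compounds below may be only part of what the source reports. "The series", "measured", "known", "first", "only" and "open" are said of these compounds alone.

Compound 1 `CC/C(=C(/c1ccc(/C=C/C(=O)O)cc1)c1ccc2[nH]ncc2n1)c1ccccc1`: 33 nM in a functional assay on MCF7 cells (Homo sapiens) for cytotoxicity, read by CellTiter-Glo, with a stated time of 5 days; a lower number here means a stronger inhibitor, a higher number a weaker inhibitor
Compound 2 `CC/C(=C(/c1ccc(/C=C/C(=O)O)cc1)c1cc(C)c2[nH]ncc2c1)c1ccccc1`: 59 nM in this assay

Among the measured compounds shown here, compound 2 holds the higher-looking of the two numbers, yet the only measured step, a 1.8-fold higher number from compound 1 to compound 2 (0.25 log units; within the scatter), lies within the scatter, so the two cannot be told apart. Compound 3 `CC/C(=C(/c1ccc(/C=C/C(=O)O)cc1)c1ccc2[nH]ncc2c1F)c1ccccc1` differs from compound 2 by 4-fluoro-1H-indazol-5-yl in place of 7-methyl-1H-indazol-5-yl on a double-bonded chain carbon bound to an aromatic carbon and a double-bonded chain carbon. For the measured compounds named here, the one step that bears on it changed the same arm and was within the scatter, and no step tests a fluorine there. The expected change from compound 2 to compound 3 in this assay is therefore small, a 1.2-fold lower number from compound 2 to compound 3 (0.07 log units; within the scatter). Compound 3 is estimated at 50 nM, with a range of 15 nM to 160 nM.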

Compound 3, half-maximal inhibitory concentration: 3 nM
For compound 3 the middle estimate is 17-fold (1.22 log units) above the measured one; the measured number lies below the stated range.
By their numbers in this assay, from the lowest: compound 3; then compounds 1 and 2 (each within the scatter of the next).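

In this assay the indazole arm on the double-bonded chain carbon proves far from indifferent. The change to 4-fluoro-1H-indazol-5-yl brings a 20-fold lower number from compound 2 to compound 3 (1.29 log units; beyond the scatter) and also an 11-fold lower number from compound 1 to compound 3 (1.04 log units; beyond the scatter) and sets compound 3 clearly apart from both. Nothing measured here accounts for the size of this change.

The step from the methyl arm adds a fluorine and removes a methyl at once, and the two cannot be told apart. A plain 1H-indazol-5-yl arm would separate them, and a 4-chloro-1H-indazol-5-yl arm would show whether fluorine itself is needed.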